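The source may report more compounds than this note shows. Statements on the series, on what has been measured and on what is new or still open speak of the compounds shown alone.

Compound 1 `CCOC(=O)c1ccsc1NC(=O)[C@@H]1CCCN1` stands at the upper edge of what this read-out reports: in a toxicity assay on HUVEC cells (Homo sapiens) for inhibition (on this read-out lower numbers stand for stronger inhibition of growth and higher numbers for weaker inhibition of growth), compound 1 gives > 250 ug/mL, a limit and not a number. Compound 2 `O=C(Oc1ccccc1)c1ccsc1NC(=O)[C@@H]1CCCN1` gives > 250 ug/mL, again a limit. Compound 3 `O=C1CC[C@@H](COC(=O)c2ccsc2NC(=O)[C@@H]2CCCN2)N1` gives 88.6 ug/mL. Two of the three values sit at the limit of > 250 ug/mL in this assay, at which 2 of the 3 values shown sit. The step from compound 1 to compound 3 reads an at least 2.8-fold lower number from compound 1 to compound 3 (0.45 log units; beyond the scatter), that from compound 2 to compound 3 reads an at least 2.8-fold lower number from compound 2 to compound 3 (0.45 log units; beyond the scatter), while that from compound 1 to compound 2 is a step that the two limits leave unreadable from compound 1 to compound 2. Compound 4 `C=CCOC(=O)c1ccsc1NC(=O)[C@@H]1CCCN1` differs from compound 1 by vinyl in place of methyl on a saturated chain carbon bound to an oxygen next to a carbonyl group. This change is small and brings in none of what enters in compound 3, so in this assay no step beyond the scatter is expected, a number no higher from compound 1 to compound 4 (the limit leaves the size open). Compound 4 is therefore estimated at 250 ug/mL, within 120 ug/mL to 500 ug/mL, most likely reported again as a limit.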

Compound 4, concentration for 50% growth inhibition: 149 ug/mL
Compound 4: middle estimate off by 1.7-fold (0.22 log units), on the high side; measured number inside the range.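

In this assay, allyloxycarbonyl gives a readable number without a ring at this place, but the comparisons with the two limit compounds give only floors: an at least 1.6-fold lower number from compound 1 to compound 4 (0.22 log units; that floor lies within the scatter), and an at least 1.6-fold lower number from compound 2 to compound 4 (0.22 log units; that floor lies within the scatter). Vinyl and 5-oxopyrrolidin-2-yl are not told apart at this place, with a 1.7-fold higher number from compound 3 to compound 4 (0.23 log units; within the scatter). A ring on this chain is therefore not required for a readable number.

The compounds shown do not separate the double bond from the added carbon, and a propyl chain would be needed for that. From the compounds shown here alone, how an amine or a carboxylic acid on this chain would read also remains open.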